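This account rests on a few compounds, and the source may have more. Where it says the series, first, only, none or still open, it means among the compounds named here.

Compound 3 `Cc1ccc(S(=O)(=O)N(CC(=O)NCc2ccc(Cl)cc2)c2cccnc2)cc1` carries a sulfonamide core with a chlorinated benzyl amide, and in a functional assay on CHO-K1 cells for antagonist activity at prostaglandin E2 receptor EP1 subtype (Homo sapiens), read by FLIPR and calcium flux (on this read-out lower numbers stand for stronger inhibition and higher numbers for weaker inhibition), compound 3 reaches only < 1450 nM, which is a limit of the assay rather than a number. Two related compounds do give numbers: compound 1 `CCc1ccccc1N(CC(=O)NCc1ccc(Br)cc1)S(=O)(=O)c1ccc(C)cc1` shows 22.9 nM, while compound 2 `CCc1ccccc1N(CC(=O)NCc1ccccc1F)S(=O)(=O)c1ccc(C)cc1` shows 135 nM, and a 5.9-fold higher number from compound 1 to compound 2 (0.77 log units; beyond the scatter). Compound 4 `Cc1ccc(S(=O)(=O)N(CC(=O)NCc2ccc(Cl)cc2)c2ccc(C)nc2)cc1` differs from compound 3 by methyl in place of hydrogen on an aromatic carbon. Within the data shown here, no measured step touches this part of the molecule; the only step, from compound 1 to compound 2, alters a different group, so it gives no direction here. Since compound 3 rests at a limit (the limit of < 1450 nM in this assay, at which 1 of the 3 values shown sits), the starting point itself is loosely fixed. For compound 4 the expectation is a step that the limit leaves unreadable from compound 3 to compound 4, nothing clearly beyond the scatter, with an estimate of 900 nM, ranging from 150 nM to 4000 nM.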

Compound 4, inhibition constant: < 1450 nM
Compound 4: a limit, no number (the forecaster's own chance of this, stated with the estimate: 35%); the middle value does not contradict the limit.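

Among these compounds, compound 3 and compound 4 each rest at a limit rather than a number, so no step between them can be read: the limit of < 1450 nM in this assay, at which 2 of the 4 values shown sit. The compounds shown leave open whether going from pyridin-3-yl to 6-methylpyridin-3-yl changes inhibition at all, in either direction.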